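A few compounds are considered here, and "the series" means these few. Any claim that something is new, unique, unknown or untested is made for them only; others in the source may bear on it.

Three compounds share one core and differ only in the aryl ketone. Compound 1 `Cc1ccc(OCC(=O)NNC(=O)c2cc3ccccc3oc2=O)c(C(=O)c2ccc(Cl)cc2)c1` gives 57800 nM in a functional assay on Ehrlich cells (Mus musculus) for cytotoxicity, read by trypan blue exclusion, with a stated time of 48 h; a higher number here means a weaker inhibitor, a lower number a stronger inhibitor; compound 2 `Cc1ccc(OCC(=O)NNC(=O)c2cc3ccccc3oc2=O)c(C(=O)c2cccc(Br)c2)c1` gives 68500 nM; compound 3 `Cc1ccc(OCC(=O)NNC(=O)c2cc3ccccc3oc2=O)c(C(=O)c2ccc(Br)cc2)c1` gives 91100 nM. Compound 3 sits at the top of these three numbers, yet a 1.6-fold higher number from compound 1 to compound 3 (0.20 log units; within the scatter) and a 1.3-fold higher number from compound 2 to compound 3 (0.12 log units; within the scatter) both lie within the scatter, as does a 1.2-fold higher number from compound 1 to compound 2 (0.07 log units; within the scatter). Compound 4 `Cc1ccc(C(=O)c2cc(C)ccc2OCC(=O)NNC(=O)c2cc3ccccc3oc2=O)cc1` differs from compound 3 by methyl in place of bromo on an aromatic carbon. Among the compounds with values here, no measured step exchanges a halogen for methyl; the three halogen swaps moved nothing beyond the scatter, so there is no ground to expect a step beyond it here either. Compound 4 is therefore expected to give 80000 nM, between 35000 nM and 180000 nM, which means an expected step of a 1.1-fold lower number from compound 3 to compound 4 (0.06 log units; within the scatter).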

Compound 4, half-maximal inhibitory concentration: 82600 nM
Beside the measured number, compound 4's estimate is 1.0-fold (0.01 log units) below it; low and high end bracket the measured number.
By their numbers in this assay, from the lowest: compounds 1, 2, 4 and 3 (each within the scatter of the next).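

Methyl is the first group at this place, on an aromatic carbon para to a large group, that is not a halogen, and in this assay a 1.1-fold lower number from compound 3 to compound 4 (0.04 log units; within the scatter) stays within the scatter. The same holds for a 1.2-fold higher number from compound 2 to compound 4 (0.08 log units; within the scatter) and for a 1.4-fold higher number from compound 1 to compound 4 (0.16 log units; within the scatter), so the change from halogen to methyl shows no measurable effect in these four compounds. No available evidence bears on this result. The compounds shown leave open whether an amine or a carboxylic acid at this place would move the number beyond the scatter.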